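Amide in Place of Urea on a Weak Antiproliferative Scaffold

This account rests on a few compounds, and the source may have more. Where it says the series, first, only, none or still open, it means among the compounds named here.

Going by the values given here, compound 2 `O=C(Nc1ccc(-n2cc(-c3ccncc3)c(-c3ccc(Cl)c(O)c3)n2)cc1)Nc1cccc(Cl)c1Cl` is the only member of this small set with a number in a functional assay on A375P cells (Homo sapiens) for antiproliferative activity, read by MTT assay, with a stated time of 48 h (on this read-out lower numbers stand for stronger inhibition and higher numbers for weaker inhibition), where compound 2 gives 16800 nM. Compound 1 `COc1cc(-c2nn(-c3ccc(NC(=O)Nc4cccc(Cl)c4Cl)cc3)cc2-c2ccncc2)ccc1Cl` reaches only a limit of the assay, > 20000 nM. Compound 3 `O=C(Nc1ccc(-n2cc(-c3ccncc3)c(-c3ccc(Cl)c(O)c3)n2)cc1)Nc1cc(C(F)(F)F)cc(C(F)(F)F)c1` likewise stops at a limit, > 20000 nM. Among the compounds with values here, the one measured step, an at least 1.1-fold lower number from compound 1 to compound 2 (0.07 log units; that floor lies within the scatter), lies within the scatter, and two of the three results sit at the limit of > 20000 nM in this assay, at which 2 of the 3 values shown sit. Within the data shown here, compound 4 `O=C(Nc1ccc(-n2cc(-c3ccncc3)c(-c3ccc(Cl)c(O)c3)n2)cc1)c1ccc(Cl)c(Cl)c1` differs from compound 2 by 3,4-dichlorophenyl in place of (2,3-dichlorophenyl)amino on a carbonyl carbon; no measured step touches this change from urea to amide, so only the value of compound 2 carries over. One therefore expects a step of a 1.1-fold lower number from compound 2 to compound 4 (0.05 log units; within the scatter), not beyond the scatter, with a real chance of another limit. For compound 4 the estimate in this assay is 15000 nM, within 3000 nM to 40000 nM.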

Compound 4, half-maximal inhibitory concentration: 6700 nM
Compound 4: the middle estimate sits 2.2-fold (0.35 log units) above what was measured, within the range that was stated.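

In this assay, going by these compounds alone, the change from urea to amide on this carbonyl carbon gives a 2.5-fold lower number from compound 2 to compound 4 (0.40 log units; beyond the scatter) as the first step in this set beyond the scatter. The change replaces (2,3-dichlorophenyl)amino with 3,4-dichlorophenyl in one move, so the loss of the nitrogen and the new chlorine placement cannot be told apart. Limits still mark much of this small set: the limit of > 20000 nM in this assay, at which 2 of the 4 values shown sit.

The compounds shown leave open whether 2,3-dichlorophenyl on the same carbonyl carbon would give a similar step. They also leave open how an amine or a carboxylic acid on that ring would read.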